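A few compounds are considered here, and "the series" means these few. Any claim that something is new, unique, unknown or untested is made for them only; others in the source may bear on it.

Measured compounds:
compound 1, `CN1CCN(CCCOc2cccc3nc(Nc4ccc(Cl)c(F)c4)ccc23)CC1`, with 1570 nM in a functional assay on UO-31 cells (Homo sapiens) for inhibition, read by sulforhodamine B assay, with a stated time of 48 h; on this read-out lower numbers stand for stronger inhibition of growth and higher numbers for weaker inhibition of growth
compound 2, `CN1CCN(CCCOc2cccc3nc(Nc4cc(Cl)cc(Cl)c4)ccc23)CC1`, with 1490 nM in this assay

Of the two numbers shown, compound 2 cannot be set apart from compound 1: the step of a 1.1-fold lower number from compound 1 to compound 2 (0.02 log units; within the scatter) lies within the scatter, so the two stand together. Compound 3, `CN1CCN(CCCOc2cccc3nc(Nc4cccc(Cl)c4)ccc23)CC1`, differs from compound 2 by hydrogen in place of chloro on an aromatic carbon. Among the compounds with values here, the only measured step, a 1.1-fold lower number from compound 1 to compound 2 (0.02 log units; within the scatter), also rearranged the halogens on that phenyl ring and left the number almost unchanged. Within the data shown here, no measured step removes a chloro group without putting anything in its place, so the expectation rests on that single comparison and on the small size of the change itself. For compound 3 a step of a 1.3-fold higher number from compound 2 to compound 3 (0.11 log units; within the scatter) in this assay is expected, which is no change beyond the scatter. Compound 3 is therefore estimated at 1900 nM, within a range of 800 nM to 4500 nM.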

Compound 3, concentration for 50% growth inhibition: 1840 nM
For compound 3 the middle estimate is 1.0-fold (0.01 log units) above the measured one, within the range that was stated.
By their numbers in this assay, from the lowest: compounds 2, 1 and 3 (each within the scatter of the next).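

In this assay, the chloro group on the 3,5-dichlorophenyl ring can be replaced by hydrogen with a result of a 1.2-fold higher number from compound 2 to compound 3 (0.09 log units; within the scatter), so a second halogen at this place on the ring is not needed to keep the number within the scatter. Within the data shown here, this is the first comparison in which a halogen leaves without another taking its place, whereas the earlier step only rearranged the halogens. The 3-chlorophenyl group also stands with the 4-chloro-3-fluorophenyl group, at a 1.2-fold higher number from compound 1 to compound 3 (0.07 log units; within the scatter), so all three rings remain together, and no measurement on hand offers an explanation for the closeness of these numbers.

Still open, on these data alone, is whether plain phenyl, with no chloro group at all, would stay with these three. Also open, as far as these compounds go, is whether a methoxy group, a nitrile or an amine at this place would move the number beyond the scatter.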